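The source may hold more compounds than are shown below. What is called first, only, known or untested is meant among the compounds shown, and "the series" means these compounds.

Compound 1 `O=C1/C(=C/c2cccc(Br)c2)CCCc2ccccc21` and compound 2 `Cc1cccc(/C=C2\CCCc3ccccc3C2=O)c1` share one core and differ only in a single substituent. In a functional assay on L1210 cells (Mus musculus) for inhibition (a higher number here means a weaker inhibitor, a lower number a stronger inhibitor), compound 1 gives 51000 nM, and compound 2 gives 54400 nM. The change between them is methyl in place of bromo on an aromatic carbon and it made a 1.1-fold higher number from compound 1 to compound 2 (0.03 log units; within the scatter). Compound 3 `O=C1CCCCC/C1=C\c1cccc(Br)c1` is built on a different core; the difference between the two cores is not broken down here. In this assay compound 3 gives 246000 nM, the highest of the three numbers. Compound 4 `Cc1cccc(/C=C2\CCCCCC2=O)c1` has not yet been measured. It differs from compound 3 by methyl in place of bromo on an aromatic carbon. Among the measured compounds shown here, this is the same kind of change as the one from compound 1 to compound 2, though the surroundings differ: here the place is meta to a group of 9 heavy atoms, there meta to a large group. Because the earlier step was a 1.1-fold higher number from compound 1 to compound 2 (0.03 log units; within the scatter) in this assay, the step is expected to be a 1.1-fold higher number from compound 3 to compound 4 (0.04 log units; within the scatter). Compound 4 is therefore estimated at 270000 nM, with a likely range from 140000 nM to 520000 nM.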

Compound 4, half-maximal inhibitory concentration: 263000 nM
Compound 4: the middle estimate sits 1.0-fold (0.01 log units) above what was measured, within the range that was stated.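

In this assay, putting methyl in place of bromo gave a 1.1-fold higher number from compound 3 to compound 4 (0.03 log units; within the scatter), so on this second core the swap again left the number about where it was. Set side by side, the two cores respond alike to this swap: the same change on two cores in this assay, a 1.1-fold higher number (0.03 log units; within the scatter) from compound 1 to compound 2 and a 1.1-fold higher number (0.03 log units; within the scatter) from compound 3 to compound 4, 1.0-fold (0.00 log units) apart, within the scatter of two such steps. This shows that the swap carried over between these two cores, at this one place and in this one assay, but it does not show that other changes or other cores would behave the same way.

The compounds shown carry only bromo or methyl at this place. From the compounds shown here alone, it remains open whether a different group there, such as an amine or a carboxylic acid, would shift the number, and whether it would do so equally on both cores.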